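A few compounds are considered here, and "the series" means these few. Any claim that something is new, unique, unknown or untested is made for them only; others in the source may bear on it.

Compound 1, `Cc1cc(Cl)ccc1NC(=O)Nc1nc(NC2CC2)cc(Sc2c[nH]c3ccccc23)n1`, gives 31500 nM in a functional assay on A549 cells (Homo sapiens) for inhibition, with a stated time of 72 h; on this read-out higher numbers stand for weaker inhibition and lower numbers for stronger inhibition. Compound 2, `O=C(Nc1ccccc1)Nc1nc(Nc2ccccc2)cc(Sc2c[nH]c3ccccc23)n1`, reaches only a limit of this assay, > 50000 nM. Compound 3, `O=C(Nc1ccccc1)Nc1nc(NC2CC2)cc(Sc2c[nH]c3ccccc23)n1`, likewise stops at a limit, > 50000 nM.

Within the data shown here, compound 1 therefore stands as the sole numerical value in this assay; the other two results are limits (the limit of > 50000 nM in this assay, at which 2 of the 3 values shown sit), so no compound can be ranked against it. Compound 4, `Cc1cc(Cl)ccc1NC(=O)Nc1nc(Sc2c[nH]c3ccccc23)cc(N2CCCC2)n1`, differs from compound 1 in one place: pyrrolidin-1-yl in place of cyclopropylamino on an aromatic carbon. Of the two measured steps, only an at least 1.5-fold higher number from compound 1 to compound 3 (0.20 log units; that floor lies within the scatter) has a readable size, and it concerns the amide-type nitrogen, not the nitrogen on the aromatic ring that changes here. The step at that ring nitrogen, a step that the two limits leave unreadable from compound 2 to compound 3, runs between two limits and gives no size. Nothing measured thus points to a direction for the change in compound 4, and no step beyond the scatter is expected. Compound 4 is estimated at 31500 nM, within 10000 nM to 100000 nM, which would mean a step of no change at the digits printed from compound 1 to compound 4 (within the scatter); the range is wide and a limit rather than a number remains a real possibility.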

Compound 4, half-maximal inhibitory concentration: 8930 nM
Estimate against measurement, compound 4: 3.5-fold (0.55 log units) above, and the stated range ends above it.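

In this assay, among these compounds, this position proves able to move the read-out, which the earlier compounds could not show: the change to pyrrolidin-1-yl on the aromatic carbon next to the ring nitrogen gives a 3.5-fold lower number from compound 1 to compound 4 (0.55 log units; beyond the scatter). The group that enters carries 0 hydrogen-bond donors against 1 in cyclopropylamino, and inhibition still grows stronger, so in this one pair the donor on that nitrogen is not needed to reach the stronger value, though the pair cannot separate the loss of the donor from the change of ring. The only earlier pair that changes a group at this place, compound 2 and compound 3, stops at a limit of the assay, and its step cannot be read: the limit of > 50000 nM in this assay, at which 2 of the 4 values shown sit.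

What the compounds shown leave open is whether the gain belongs to the five-membered ring itself or to any group without a donor on that nitrogen, a question that piperidin-1-yl, morpholin-4-yl or dimethylamino at this place would bear on. As far as these compounds go, it also stays open whether pyrrolidin-1-yl gives a similar step when phenyl replaces 4-chloro-2-methylphenyl on the amide-type nitrogen.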